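The source may hold more compounds than are shown below. What is called first, only, known or untested is meant among the compounds shown, and "the series" means these compounds.

Compound 1 `CCCCCCc1cc2cn(Cc3cn(-c4ccccc4F)nn3)c(=O)nc2o1` in a functional assay on A549 cells (Homo sapiens) for antiproliferative activity, read by MTT assay, with a stated time of 72 h (a lower number here means a stronger inhibitor, a higher number a weaker inhibitor), gives > 100000 nM, which is a limit of the assay rather than a number.
Compound 2 `O=c1nc2oc(CCCCl)cc2cn1Cc1cn(-c2ccccc2F)nn1` gives 69800 nM.

Among the compounds with values here, compound 2 thus carries the only numeric value here; the step of an at least 1.4-fold lower number from compound 1 to compound 2 (0.15 log units; that floor lies within the scatter) is the sole measured comparison, and it concerns the chain, not the triazole substituent. Compound 3 `O=c1nc2oc(CCCCl)cc2cn1Cc1cn(Cc2ccccc2)nn1` differs from compound 2 by benzyl in place of 2-fluorophenyl on an aromatic nitrogen. Within the data shown here, no measured step touches this position, so no direction can be drawn from the data, and a change within the scatter is the plain expectation. Compound 3 is estimated at 70000 nM (range 20000 nM to 250000 nM), an expected step of a 1.0-fold higher number from compound 2 to compound 3 (0.00 log units; within the scatter).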

Compound 3, half-maximal inhibitory concentration: 27900 nM
Compound 3: the middle estimate sits 2.5-fold (0.40 log units) above what was measured; measured number inside the range.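

Within the data shown here, with the chain held fixed, the group on the triazole nitrogen matters in this assay: benzyl in place of 2-fluorophenyl gives a 2.5-fold lower number from compound 2 to compound 3 (0.40 log units; beyond the scatter) and thus the first change beyond the scatter. Among these compounds, the earlier compounds showed only a change on the chain, so this is the first measured effect at this position. Nothing measured here explains why benzyl gives the lower number.

From the compounds shown here alone, whether an unsubstituted phenyl, a phenethyl group or an amine-bearing benzyl at this position would lower the number further remains open. So does whether benzyl would give a similar step on the chain of compound 1.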